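Moving a methoxy group around the ring

This account rests on a few compounds, and the source may have more. Where it says the series, first, only, none or still open, it means among the compounds named here.

Measured compounds:
- compound 1, `O=C(NO)c1ccc(Cn2ccc3cc(C(=O)c4ccc(F)cc4)ccc32)cc1`, 1240 nM in an assay on isolated protein for inhibition of histone deacetylase 8 (Homo sapiens); a lower number here means a stronger inhibitor, a higher number a weaker inhibitor
- compound 2, `COc1ccc(C(=O)c2ccc3c(ccn3Cc3ccc(C(=O)NO)cc3)c2)cc1`, 646 nM in this assay

Compound 2 gives the lower of the two numbers, but the step of a 1.9-fold lower number from compound 1 to compound 2 (0.28 log units; within the scatter) is within the scatter, so the two compounds cannot be told apart on these data. Compound 3, `COc1cccc(C(=O)c2ccc3c(ccn3Cc3ccc(C(=O)NO)cc3)c2)c1`, has not yet been measured. It differs from compound 2 only in 3-methoxyphenyl in place of 4-methoxyphenyl on a carbonyl carbon: the same atoms are present, joined differently. Going by the values given here, the single measured step, a 1.9-fold lower number from compound 1 to compound 2 (0.28 log units; within the scatter), exchanged one group for another at the same spot and left the number within the scatter; no measured step moves a group from one spot to another, so that comparison bears only loosely on this change. With nothing pointing in either direction, compound 3 is expected to land near compound 2, with the step of a 1.1-fold higher number from compound 2 to compound 3 (0.03 log units; within the scatter) likely inside the scatter. Compound 3 is therefore estimated at 700 nM in this assay, with a range of 300 nM to 1600 nM.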

Compound 3, half-maximal inhibitory concentration: 1120 nM
The estimate for compound 3 lay 1.6-fold (0.20 log units) below the measured number, within the range that was stated.
By their numbers in this assay, from the lowest: compounds 2, 3 and 1 (each within the scatter of the next).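

Going by these compounds alone, this is the first step here that moves a group instead of exchanging it: 3-methoxyphenyl in place of 4-methoxyphenyl on a carbonyl carbon gives a 1.7-fold higher number from compound 2 to compound 3 (0.24 log units; within the scatter) in this assay and so leaves these two arrangements of the same atoms indistinguishable. Putting 3-methoxyphenyl in place of 4-fluorophenyl at that carbonyl carbon gives a 1.1-fold lower number from compound 1 to compound 3 (0.04 log units; within the scatter) and so shows that all three groups seen at this position sit within the scatter of one another. No outside measurement is available that bears on these small differences.

The compounds shown carry only a methoxy group or a fluorine on this ring. From the compounds shown here alone, whether an amine, a carboxylic acid or a longer chain such as butoxy there would shift the number beyond the scatter remains open.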